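Fluoro for Trifluoromethyl on Two Different Rings

The source may hold more compounds than are shown below. What is called first, only, known or untested is meant among the compounds shown, and "the series" means these compounds.

Measured so far in a functional assay on QGY-7703 cells (Homo sapiens) for cytotoxicity, read by MTT assay, with a stated time of 24 h; a lower number here means a stronger inhibitor, a higher number a weaker inhibitor:
compound 1 `CN1C/C(=C\c2ccncc2)C(=O)/C(=C/c2ccccc2F)C1` gives 4900 nM;
compound 2 `CN1C/C(=C\c2ccncc2)C(=O)/C(=C/c2ccccc2C(F)(F)F)C1` gives 4500 nM;
compound 3 `O=C1/C(=C/c2cccnc2)CN(S(=O)(=O)c2ccc(C(F)(F)F)cc2)C/C1=C\c1ccccc1F` gives 4500 nM.

Compound 1 differs from compound 2 by fluoro in place of trifluoromethyl on an aromatic carbon, and that change made a step of a 1.1-fold higher number from compound 2 to compound 1 (0.04 log units; within the scatter). Compound 3 has a different core from compound 2, and how the two cores differ is not broken down here. Compound 4 `O=C1/C(=C/c2cccnc2)CN(S(=O)(=O)c2ccc(F)cc2)C/C1=C\c1ccccc1F` differs from compound 3 by fluoro in place of trifluoromethyl on an aromatic carbon. This is the same kind of change, not the same one: in compound 2 the group sits ortho to a large group, in compound 3 para to a large group. The step from compound 3 to compound 4 in this assay is expected to be a 1.1-fold higher number from compound 3 to compound 4 (0.05 log units; within the scatter), resting on the earlier step of a 1.1-fold higher number from compound 2 to compound 1 (0.04 log units; within the scatter), which stayed within the scatter. Compound 4 is therefore estimated at 5000 nM, between 2200 nM and 11000 nM.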

Compound 4, half-maximal inhibitory concentration: 15300 nM
Compound 4: the middle estimate sits 3.1-fold (0.49 log units) below what was measured; measured number outside the range, above it.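

In this assay, replacing 4-(trifluoromethyl)phenyl with 4-fluorophenyl gave a 3.4-fold higher number from compound 3 to compound 4 (0.53 log units; beyond the scatter). The same kind of change therefore did not carry over at the same size from one core to the other: the same change on two cores in this assay, a 1.1-fold higher number (0.04 log units; within the scatter) from compound 2 to compound 1 and a 3.4-fold higher number (0.53 log units; beyond the scatter) from compound 3 to compound 4, 3.1-fold (0.49 log units) apart, beyond the scatter of two such steps. Among these compounds, with only one pair on each core, this does not show whether the core itself or the place where the group sits sets the size of the step, as the two pairs differ in both.

The compounds shown leave open how a chlorine, a methoxy group or a nitrile would behave at this place on the ring. They also leave open whether this change would give a similar step on a third core.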